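Shortening the amide side chain from methylpyridine to pyridine

This account rests on a few compounds, and the source may have more. Where it says the series, first, only, none or still open, it means among the compounds named here.

Measured so far:
- compound 1 `O=C(Cn1c(=O)oc2ccccc21)NCc1ccccn1`: 37.3%
- compound 2 `O=C(Cn1c(=O)oc2cc(Cl)ccc21)NCc1ccco1`: 27.8%

In an ADME assay on RAW264.7 cells (Mus musculus) for cytotoxicity, read by MTT assay, with a stated time of 72 h, tested at 50 uM (a higher number here means a stronger effect of the compound at the concentration tested, a lower number a weaker effect), compound 1 gives 37.3% and compound 2 gives 27.8%; the two numbers sit within the usual scatter of each other, so neither stands apart. Compound 3 `O=C(Cn1c(=O)oc2ccccc21)Nc1ccccn1` is not yet measured. It differs from compound 1 in one place: pyridin-2-yl in place of (pyridin-2-yl)methyl on an amide-type nitrogen. Going by the values given here, with no measured step of this kind to lean on, the step of a number 4.3 percentage points lower from compound 1 to compound 3 (within the scatter) is expected to stay within the scatter, in no clear direction. Compound 3 is therefore estimated at 33%, with a range from 15% to 55%.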

Compound 3, a percentage reported as inhibition, at one concentration (the size of the read-out at that concentration, not a potency): 20.2%
Compound 3: middle estimate off by 12.8 percentage points, on the high side, within the range that was stated.
By their numbers in this assay, from the lowest: compounds 3, 2 and 1 (each within the scatter of the next, the first and the last beyond it).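

Going by these compounds alone, this is the first measured change on the amide-type nitrogen: in this assay, pyridin-2-yl in place of (pyridin-2-yl)methyl gives a number 17.1 percentage points lower from compound 1 to compound 3 (beyond the scatter). Although modest, the step shows that the read-out at this position is sensitive to this small change in the side chain. No measurement at hand says why the number moves.

As far as these compounds go, it remains open whether a longer chain, such as 2-(pyridin-2-yl)ethyl, would raise the number further. A benzyl or phenyl group would test whether the ring nitrogen matters at all.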